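Swapping the aryl halogen pattern on compound 2

The source may report more compounds than this note shows. Statements on the series, on what has been measured and on what is new or still open speak of the compounds shown alone.

Compounds with values in a functional assay on A549 cells (Homo sapiens) for antiproliferative activity, read by MTT assay, with a stated time of 48 h; on this read-out higher numbers stand for weaker inhibition and lower numbers for stronger inhibition:
Compound 1 `N#CC1=C(N)Oc2c(c3nc4ccccc4nc3c3ccccc23)C12C(=O)N(Cc1cnnn1-c1ccc(Br)cc1)c1ccccc12` gives 44300 nM in this assay.
Compound 2 `N#CC1=C(N)Oc2c(c3nc4ccccc4nc3c3ccccc23)C12C(=O)N(Cc1cnnn1-c1cccc(Br)c1)c1ccccc12` gives only a limit of this assay, > 50000 nM, not a number.
Compound 3 `Cc1ccc(Cl)cc1-n1nncc1CN1C(=O)C2(C(C#N)=C(N)Oc3c2c2nc4ccccc4nc2c2ccccc32)c2ccccc21` likewise gives only a limit of this assay, > 50000 nM.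

Compound 2 therefore stands at the limit of this assay rather than at a measured number, and it shares that position with compound 3, as the limit of > 50000 nM in this assay, at which 2 of the 3 values shown sit, records. Among the three, only compound 1 carries a number. The step of an at least 1.1-fold higher number from compound 1 to compound 2 (0.05 log units; that floor lies within the scatter) and the step of an at least 1.1-fold higher number from compound 1 to compound 3 (0.05 log units; that floor lies within the scatter) both have floors inside the usual scatter, so neither can be called a real change, and the step that the two limits leave unreadable from compound 2 to compound 3 cannot be read at all.

Compound 4 `N#CC1=C(N)Oc2c(c3nc4ccccc4nc3c3ccccc23)C12C(=O)N(Cc1cnnn1-c1ccc(F)c(Cl)c1)c1ccccc12` differs from compound 2 by 3-chloro-4-fluorophenyl in place of 3-bromophenyl on an aromatic nitrogen. The measured steps that bear on this change are the three exchanges of the aryl group on the aromatic nitrogen, and none of them resolved into a readable size or direction. The expected step of a number no higher from compound 2 to compound 4 (the limit leaves the size open) is accordingly no change beyond the scatter. Compound 4 is expected to give about 50000 nM in this assay, within 25000 nM to 100000 nM, and most probably this assay will again report only a limit for compound 4.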

Compound 4, half-maximal inhibitory concentration: > 50000 nM
Compound 4: a limit, no number (the forecaster's own chance of this, stated with the estimate: 70%); the middle value lies on the limit itself.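

In this assay, the 3-chloro-4-fluorophenyl group on the aromatic nitrogen yields a limit and no number, as the 3-bromophenyl and 5-chloro-2-methylphenyl groups did, so a third substitution pattern on this aryl group now ends at the limit. Against the only compound with a number, the change reads as an at least 1.1-fold higher number from compound 1 to compound 4 (0.05 log units; that floor lies within the scatter), so no real change is shown, and the steps to compound 4 from the two other compounds held at the limit cannot be read. Across the four compounds, the limit has become the usual result at this position, with compound 1 the only exception: the limit of > 50000 nM in this assay, at which 3 of the 4 values shown sit.

Every compound shown carries a halogen on this phenyl ring, and whether an amine or a carboxylic acid there, or a longer chain in place of the ring, would give a number in this assay stays open. Also open, as far as these compounds go, is how far the true values of compound 2, compound 3 and compound 4 lie from their shared limit, and so whether these three differ from one another at all.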